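Nitro in place of (propylcarbonyl)amino on a shared core

This account rests on a few compounds, and the source may have more. Where it says the series, first, only, none or still open, it means among the compounds named here.

In a functional assay on KB cells (Homo sapiens) for cytotoxicity (a higher number here means a weaker inhibitor, a lower number a stronger inhibitor), compound 1 (`CCCC(=O)Nc1cc(Cl)ccc1Sc1ccccc1`) gives > 300 ug/mL and this is a limit of the assay, not a number. Compound 1 therefore stands at the limit of > 300 ug/mL in this assay, at which 1 of the 3 values shown sits, with no measured value as a starting point. In this assay compound 2 (`O=C(Nc1cc(Cl)ccc1Sc1ccccc1)c1ccccc1`) gives 9 ug/mL and compound 3 (`O=C(Nc1cc(Cl)ccc1Sc1ccccc1)c1ccc([N+](=O)[O-])cc1`) gives 223 ug/mL on the same scale. Compound 4 (`O=[N+]([O-])c1cc(Cl)ccc1Sc1ccccc1`) has not been measured. Going by the values given here, it carries nitro in place of (propylcarbonyl)amino on an aromatic carbon and no measured step makes this exchange. Among the compounds with values here, two steps bear on it only indirectly. One is an at least 33-fold lower number from compound 1 to compound 2 (1.52 log units; beyond the scatter) and the other is a 25-fold higher number from compound 2 to compound 3 (1.39 log units; beyond the scatter) with nitro entering elsewhere. Both are large but point in opposite directions, so only a moderate step towards a lower number is expected in this assay and it may not be resolved. This expectation amounts to an at least 3.0-fold lower number from compound 1 to compound 4 (0.47 log units; beyond the scatter) as an estimate. The estimate for compound 4 is 100 ug/mL with an expected range from 20 ug/mL to 300 ug/mL in this assay.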

Compound 4, half-maximal inhibitory concentration: 43.1 ug/mL
Compound 4: the middle estimate sits 2.3-fold (0.37 log units) above what was measured; the measured number falls inside the stated range.
By their numbers in this assay, from the lowest: compound 2; then compound 4; then compound 3. At a limit, above all of these: compound 1.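

Compound 1, compound 2 and compound 3 all keep an amide on this aromatic carbon and vary only what its carbonyl carries, whereas compound 4 has no amide there at all, and in this assay this exchange gives an at least 6.9-fold lower number from compound 1 to compound 4 (0.84 log units; beyond the scatter). A measured value in this assay therefore does not require an amide at this position: nitro, which has no hydrogen-bond donor, also gives one. Compound 1 gives > 300 ug/mL, which is a limit of the assay and not a number, so the size of this step is known from one side only: the limit of > 300 ug/mL in this assay, at which 1 of the 4 values shown sits.

The compounds shown leave open how a free amine or a carboxylic acid on this aromatic carbon would read in this assay. They also do not separate the loss of the (propylcarbonyl)amino group from the entry of nitro as the source of the step.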